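Replacing the 5-chloropyridin-2-yl group on the amide

The compounds below may be only part of what the source reports. "The series", "measured", "known", "first", "only" and "open" are said of these compounds alone.

In a functional assay on HCT-116 cells (Homo sapiens) for cytotoxicity, read by MTT assay (a lower number here means a stronger inhibitor, a higher number a weaker inhibitor), compound 2 (`CCn1cc(C(=O)Nc2ccc(Cl)cn2)c(=O)c2cc(F)c(N3CCNC(C)C3)c(F)c21`) gives 3300 nM, the middle of three measured numbers. Compound 1 (`CCn1cc(-c2nc3ccc([N+](=O)[O-])cc3o2)c(=O)c2cc(F)c(N3CCNC(C)C3)c(F)c21`) gives a lower 1100 nM, and compound 3 (`CCn1cc(C(=O)Nc2ccc(C)c([N+](=O)[O-])c2)c(=O)c2cc(F)c(N3CCNC(C)C3)c(F)c21`) a higher 11800 nM. Compound 4 (`CCn1cc(C(=O)Nc2ccc(C(C)=O)cc2)c(=O)c2cc(F)c(N3CCNC(C)C3)c(F)c21`) has 4-acetylphenyl in place of 5-chloropyridin-2-yl on an amide-type nitrogen. Among the compounds with values here, only one measured step bears on this change: a 3.6-fold higher number from compound 2 to compound 3 (0.55 log units; beyond the scatter), where 4-methyl-3-nitrophenyl enters at the same nitrogen. That single modest rise is thin evidence, but it points the same way for another substituted phenyl. The expected step is therefore a modest rise of similar or smaller size, a 2.1-fold higher number from compound 2 to compound 4 (0.33 log units; beyond the scatter). Compound 4 is estimated at 7000 nM, with an expected range of 2500 nM to 20000 nM.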

Compound 4, half-maximal inhibitory concentration: 4600 nM
For compound 4 the middle estimate is 1.5-fold (0.18 log units) above the measured one; the measured number falls inside the stated range.
By their numbers in this assay, from the lowest: compound 1; then compounds 2 and 4 (each within the scatter of the next); then compound 3.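

In this assay, a 1.4-fold higher number from compound 2 to compound 4 (0.14 log units; within the scatter) lies within the scatter, so swapping 5-chloropyridin-2-yl for 4-acetylphenyl on the amide-type nitrogen leaves no readable change. With a 2.6-fold lower number from compound 3 to compound 4 (0.41 log units; beyond the scatter), the two carbon-only aromatic rings also differ, so the rise seen with 4-methyl-3-nitrophenyl does not extend to every substituted phenyl here. Nothing available explains why these two substituted phenyl groups part. Open, on these data alone, is whether a phenyl ring carrying an amine or a carboxylic acid would fall with compound 2 and compound 4 or with compound 3.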